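The source may report more compounds than this note shows. Statements on the series, on what has been measured and on what is new or still open speak of the compounds shown alone.

Measured so far in a functional assay on cells for antagonist activity at C-X-C chemokine receptor type 4 (Homo sapiens), read by fluorescence and calcium flux, with stated times of 25 min and 90 s; a lower number here means a stronger inhibitor, a higher number a weaker inhibitor:
compound 1 `c1cncc(CNCCCCN(C[C@H]2Cc3ccccc3CN2)[C@H]2CCCc3cccnc32)c1` gives 15.3 nM;
compound 2 `c1ccc2c(c1)CN[C@@H](CN(CCCCNCC1CCCCC1)[C@H]1CCCc3cccnc31)C2` gives 158 nM;
compound 3 `FC1(F)CCC(NCc2ccc(CN(C[C@H]3Cc4ccccc4CN3)[C@H]3CCCc4cccnc43)cc2)CC1` gives 143 nM.

Compound 3 stands second highest of the three numbers. Its value and that of compound 2 lie within the scatter of one another, so no order between them can be read. Against compound 1 the number of compound 3 is clearly higher, the two values being separated beyond the scatter.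

Compound 4 `c1ccc(CNCc2ccc(CN(C[C@H]3Cc4ccccc4CN3)[C@H]3CCCc4cccnc43)cc2)nc1` differs from compound 3 in one place: (pyridin-2-yl)methyl in place of 4,4-difluorocyclohexyl on an amine nitrogen. Among the compounds with values here, the one measured step that bears on this is a 10-fold higher number from compound 1 to compound 2 (1.01 log units; beyond the scatter), where cyclohexyl replaced pyridin-3-yl on a saturated chain carbon bound to an amine nitrogen. The change from compound 3 to compound 4 runs the other way, a saturated ring leaving and a pyridine ring entering, though here the entering group is (pyridin-2-yl)methyl rather than a bare pyridinyl and the attachment is on the amine nitrogen itself. The number for compound 4 in this assay is therefore expected to fall, by a step of about a 4.8-fold lower number from compound 3 to compound 4 (0.68 log units; beyond the scatter). Compound 4 is estimated at 30 nM in this assay, with a range from 10 nM to 90 nM.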

Compound 4, half-maximal inhibitory concentration in the C-X-C chemokine receptor type 4 assay: 286 nM
For compound 4 the middle estimate is 9.5-fold (0.98 log units) below the measured one, outside the stated range (above it).
By their numbers in the C-X-C chemokine receptor type 4 assay, from the lowest: compound 1; then compounds 3, 2 and 4 (each within the scatter of the next).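

In the C-X-C chemokine receptor type 4 assay compound 3 gives 143 nM and compound 4 gives 286 nM, and the exchange of 4,4-difluorocyclohexyl for (pyridin-2-yl)methyl on this amine nitrogen gives a 2.0-fold higher number from compound 3 to compound 4 (0.30 log units; within the scatter), so at this place the two groups cannot be told apart. The earlier exchange between a pyridine ring and a saturated ring, a 10-fold higher number from compound 1 to compound 2 (1.01 log units; beyond the scatter), lay beyond the scatter, but its size does not carry over to this pair, where both the groups and the place differ. No measurement at hand accounts for the contrast between the two steps.

In a physicochemical assay for permeability, using PAMPA, with a stated time of 4 h, at pH 7.4, tested at 100 uM (a higher number here means that the compound crosses the layer faster, a lower number that the compound crosses the layer more slowly), compound 3 gives 5 nm/s, while compound 4 is recorded as "not determined" (no result reported), so the step between them cannot be read for that measurement. Within the data shown here, still open is whether (pyridin-3-yl)methyl and cyclohexylmethyl, placed on this same amine nitrogen in the core shared by compound 3 and compound 4, would be separated in the C-X-C chemokine receptor type 4 assay by a step as large as the one from compound 1 to compound 2, or would also stay within the scatter.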